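Dimethylamino in Place of Acetyl: Both Parents at the Limit

The source may report more compounds than this note shows. Statements on the series, on what has been measured and on what is new or still open speak of the compounds shown alone.

Compound 1 `COc1cc(C)cc(-c2c(-c3ccnc(-c4ccc(C(C)=O)cc4)c3)cnn2CC#N)c1` was tested in a functional assay on NCI-H23 cells (Homo sapiens) for inhibition, read by sulforhodamine B assay, with a stated time of 48 h; a higher number here means that more compound is tolerated, a lower number that less compound is tolerated. In this assay compound 1 gives > 100000 nM, a limit of the assay rather than a number. Compound 2 `COc1cc(C)cc(-c2nn(CC#N)cc2-c2ccnc(-c3ccc(N(C)C)cc3)c2)c1` likewise gives > 100000 nM, again a limit. Compound 1 therefore stands at the limit of > 100000 nM in this assay, at which 2 of the 2 values shown sit. Compound 3 `COc1cc(C)cc(-c2c(-c3ccnc(-c4ccc(N(C)C)cc4)c3)cnn2CC#N)c1` has not yet been measured; it differs from compound 1 by dimethylamino in place of acetyl on an aromatic carbon. With both measured compounds at the limit, no step beyond the scatter is expected, and compound 3 is expected to give about 100000 nM, in a range from 30000 nM to 300000 nM. The expected step, a number no higher from compound 1 to compound 3 (the limit leaves the size open), lies within the scatter.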

Compound 3, concentration lethal to 50% of the cells: > 100000 nM
Compound 3: only a limit was reported; the forecaster's own chance of this, stated with the estimate: 75%; the middle value sits exactly at the limit.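

Compound 1 and compound 3 both stop at a limit of the assay, not at a number, so no step can be read between them: the limit of > 100000 nM in this assay, at which 3 of the 3 values shown sit.

From the compounds shown here alone, whether dimethylamino in place of acetyl changes anything in this assay stays open, as does the actual value of each compound.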